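Adding a chloro group to two different cores

This account rests on a few compounds, and the source may have more. Where it says the series, first, only, none or still open, it means among the compounds named here.

Compound 1, `CC(=O)OC/C(=C\c1ccc(Cl)cc1)C(=O)c1ccccc1`: 2300 nM
Compound 2, `CC(=O)OC/C(=C\c1ccc(Cl)cc1Cl)C(=O)c1ccccc1`: 3100 nM
Compound 3, `C=C(C/C(=C\c1ccccc1)C(=O)c1ccccc1)C(=O)c1ccccc1`: 10000 nM

All three values come from a functional assay on HBL-100 cells (Homo sapiens) for inhibition, read by sulforhodamine B assay, with a stated time of 48 h; a lower number here means a stronger inhibitor of growth, a higher number a weaker inhibitor of growth. Compound 1 and compound 2 differ in one place, (chloro in place of hydrogen on an aromatic carbon), and this gave a 1.3-fold higher number from compound 1 to compound 2 (0.13 log units; within the scatter). Compound 3 has a different core, and the difference between the two cores is not broken down here; its value is the highest of the three, beyond the scatter from compound 2 and from compound 1.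

Compound 4, `C=C(C/C(=C\c1ccc(Cl)cc1)C(=O)c1ccccc1)C(=O)c1ccccc1`, has not yet been measured. It differs from compound 3 by chloro in place of hydrogen on an aromatic carbon. Among the compounds with values here, this is the same kind of change as the one from compound 1 to compound 2, but not the same: in compound 2 the new chloro sits ortho to a large group and meta to a chloro group, while in compound 4 it sits para to a large group. Because a 1.3-fold higher number from compound 1 to compound 2 (0.13 log units; within the scatter) stayed within the scatter, the step expected for compound 4 is also small, a 1.1-fold lower number from compound 3 to compound 4 (0.05 log units; within the scatter). In this assay compound 4 is therefore estimated at 9000 nM, with a range from 4500 nM to 18000 nM.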

Compound 4, concentration for 50% growth inhibition: 17000 nM
Compound 4: the middle estimate sits 1.9-fold (0.28 log units) below what was measured; low and high end bracket the measured number.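

In this assay, the change from phenyl to 4-chlorophenyl gave a 1.7-fold higher number from compound 3 to compound 4 (0.23 log units; within the scatter), so on this core the added chloro group made no difference that can be told from the scatter. The earlier step on the other core points the same way, and the two steps cannot be told apart: the same change on two cores in this assay, a 1.3-fold higher number (0.13 log units; within the scatter) from compound 1 to compound 2 and a 1.7-fold higher number (0.23 log units; within the scatter) from compound 3 to compound 4, 1.3-fold (0.10 log units) apart, within the scatter of two such steps. Within the data shown here, this shows that, across these two pairs, adding a chloro group left the number about where it was on both cores, but it does not show that the same would hold on any other core, and the step is not an exact repeat, as the new chloro in compound 2 and the one in compound 4 stand in different places.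

On these data alone, the aromatic rings that change here carry only hydrogen or chloro, so it stays open whether an amine or a carboxylic acid in the same place would move the number beyond the scatter. As far as these compounds go, whether a chloro step stays this small on a third core also remains open.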